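The source may report more compounds than this note shows. Statements on the series, on what has been measured and on what is new or still open speak of the compounds shown alone.

Compound 1 `CCCS(=O)(=O)c1cccc(C#Cc2c(Cl)cccc2OCC(=O)O)c1` gives 55 nM in an assay on CHO cells for displacement of a labelled ligand from prostaglandin D2 receptor 2 (Homo sapiens), read by scintillation counting (a higher number here means a weaker inhibitor, a lower number a stronger inhibitor), and compound 2 `CCCS(=O)(=O)c1cccc(C#Cc2c(OCC(=O)O)cccc2-c2ccsc2)c1` gives 18 nM in this assay. For the measured compounds named here, the only measured step, a 3.1-fold lower number from compound 1 to compound 2 (0.49 log units; beyond the scatter), is a modest one that lies beyond the scatter. Going by the values given here, compound 2 therefore stands at the lowest of the two numbers so far, with compound 1 as its only neighbour at the higher number.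

Compound 3 `CCCS(=O)(=O)c1cccc(C#Cc2c(OCC(=O)O)cccc2-c2sc(C)nc2C)c1` differs from compound 2 in one place: 2,4-dimethyl-1,3-thiazol-5-yl in place of thiophen-3-yl on an aromatic carbon. Among the compounds with values here, the one measured step that touches this position is a 3.1-fold lower number from compound 1 to compound 2 (0.49 log units; beyond the scatter), which exchanged chloro for thiophen-3-yl on the same aromatic carbon. The present change keeps a five-membered aromatic ring at that carbon and alters the ring itself, a kind of change that the two measured compounds do not cover. Nothing among them argues for a step beyond the scatter in either direction. Compound 3 is therefore expected to give about 22 nM in this assay, with a range of 8 nM to 60 nM. The expected step of a 1.2-fold higher number from compound 2 to compound 3 (0.09 log units; within the scatter) is estimated to stay within the scatter.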

Compound 3, inhibition constant: 54 nM
Beside the measured number, compound 3's estimate is 2.5-fold (0.39 log units) below it; measured number inside the range.
By their numbers in this assay, from the lowest: compound 2; then compounds 3 and 1 (each within the scatter of the next).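

For the compounds shown here, at this aromatic carbon, the five-membered aromatic rings are not interchangeable: in this assay the change shows a 3.0-fold higher number from compound 2 to compound 3 (0.48 log units; beyond the scatter) and so is a modest step, something the earlier pair could not reveal because it held only one such ring. The lower number that came with thiophen-3-yl in place of chloro therefore does not extend to every five-membered aromatic ring placed here, for 2,4-dimethyl-1,3-thiazol-5-yl in place of chloro gives a 1.0-fold lower number from compound 1 to compound 3 (0.01 log units; within the scatter) and leaves the two compounds within the scatter of each other. The entering group differs from thiophen-3-yl in both its ring nitrogen and its two methyl groups, and nothing at hand explains the size of this step.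

As far as these compounds go, whether the step follows the ring nitrogen or the two methyl groups stays open, and an unsubstituted 1,3-thiazol-5-yl or a dimethylthiophen-3-yl would separate the two. Also open, from the compounds shown here alone, is how a six-membered pyridinyl ring, or a saturated group such as morpholin-4-yl, would read at this carbon in this assay on the same core.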